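A Ring Swap on Compound 1, Expected Within Scatter

The source may hold more compounds than are shown below. What is called first, only, known or untested is meant among the compounds shown, and "the series" means these compounds.

Compound 1 `O=C(O)c1cc(C2N=NN=N2)ccc1O` carries a five-membered ring on the shared core. In a functional assay on the whole organism for inhibition, with Rattus norvegicus as the target, read by paw edema (a higher number here means that more compound is needed for the effect, a lower number that less compound is needed), compound 1 gives 110 mg/kg. Compound 3 `O=C(O)c1cc(-n2nccn2)ccc1O` gives 150 mg/kg and compound 2 `O=C(O)c1ccc(-c2cscn2)cc1O` gives 70 mg/kg; both numbers lie within the usual scatter of the number for compound 1, so the three measured compounds cannot be told apart. The step of a 1.4-fold higher number from compound 1 to compound 3 (0.13 log units; within the scatter) shows that exchanging the ring of compound 1 for another five-membered aromatic ring left the read-out unchanged beyond the scatter. Compound 4 `O=C(O)c1cc(-c2ccno2)ccc1O` differs from compound 1 in the same place: a group of 5 heavy atoms (3 carbon, 1 nitrogen, 1 oxygen; one five-membered aromatic ring with 2 hetero atoms) in place of a group of 5 heavy atoms (1 carbon, 4 nitrogen; one five-membered non-aromatic ring with 4 hetero atoms), on an aromatic carbon. Among the measured compounds shown here, because the one comparable step a 1.4-fold higher number from compound 1 to compound 3 (0.13 log units; within the scatter) stayed within the scatter, the expected step for compound 4 is a 1.1-fold lower number from compound 1 to compound 4 (0.04 log units; within the scatter), no change beyond the scatter. The estimate for compound 4 is 100 mg/kg, with a range from 50 mg/kg to 200 mg/kg.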

Compound 4, dose for half-maximal effect: 110 mg/kg
The estimate for compound 4 lay 1.1-fold (0.04 log units) below the measured number; the measured number falls inside the stated range.
By their numbers in this assay, from the lowest: compounds 2, 1, 4 and 3 (each within the scatter of the next, the first and the last beyond it).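

At this position on the shared core, 1,2-oxazol-5-yl replaces the non-aromatic ring with no change at the digits printed from compound 1 to compound 4 (within the scatter), and replaces 2H-1,2,3-triazol-2-yl with a 1.4-fold lower number from compound 3 to compound 4 (0.13 log units; within the scatter). A second five-membered aromatic ring, with 2 hydrogen-bond acceptors where the non-aromatic ring has 4, thus keeps the number in this assay within the scatter. No information at hand explains this result.

Still open, going by these compounds, is whether any group at this position can move the number beyond the scatter, such as an amine or a longer carbon chain in place of the five-membered ring.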